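The compounds below may be only part of what the source reports. "The series", "measured", "known", "first", "only" and "open" are said of these compounds alone.

Compound 1 `O=C(O)CC[C@H](NC(=O)CN(c1nc(Cl)nc2[nH]cnc12)C1CC1)C(=O)O` gives 29.5% in a functional assay on the whole organism (Tail, strain ICR) with Mus musculus as the target, in the tail flick test, with a stated time of 150 min, at a dose of 25 umol/kg by the oral route; a lower number here means a weaker effect, a higher number a stronger effect of the compound at the dose given.
Compound 2 `NC(=O)CC[C@H](NC(=O)CN(c1nc(Cl)nc2[nH]cnc12)C1CC1)C(=O)O` gives 11.4%.
Compound 3 `NC(=O)C[C@H](NC(=O)CN(c1nc(Cl)nc2[nH]cnc12)C1CC1)C(=O)OCc1ccccc1` gives 13.5%.

Compound 3 holds the second highest of the three numbers in this assay: its value sits within the scatter of compound 2 and lies beyond the scatter below compound 1. Compound 4 `NC(=O)C[C@H](NC(=O)CN(c1nc(Cl)nc2[nH]cnc12)C1CC1)C(=O)O` is reached from compound 3 by hydrogen in place of benzyl on an oxygen next to a carbonyl group. Among the compounds with values here, the one measured step between neighbours, a number 18.1 percentage points lower from compound 1 to compound 2 (beyond the scatter), concerns a different change, amino in place of hydroxy, so it does not bear on this one; no measured pair shows benzyl giving way to hydrogen on an oxygen next to a carbonyl group. An expectation for compound 4 therefore rests only on the spread of the three numbers, and the step of a number 4.5 percentage points higher from compound 3 to compound 4 (within the scatter) is expected to stay small. Compound 4 is estimated at 18%, from 5% to 35%.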

Compound 4, a percentage reported as activity, at one dose (the size of the read-out at that dose, not a potency): 7.51%
Beside the measured number, compound 4's estimate is 10.5 percentage points above it; low and high end bracket the measured number.
By their numbers in this assay, from the lowest: compounds 4, 2 and 3 (each within the scatter of the next); then compound 1.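

Benzyl giving way to hydrogen on an oxygen next to a carbonyl group, benzyloxycarbonyl to carboxy, now has a measured case: in this assay it gives a number 6 percentage points lower from compound 3 to compound 4 (within the scatter), so the two forms cannot be told apart here. Carbamoyl in place of carbamoylmethyl gives a number 3.9 percentage points lower from compound 2 to compound 4 (within the scatter), while carbamoyl in place of carboxymethyl gives a number 22 percentage points lower from compound 1 to compound 4 (beyond the scatter), so among these side chains only carboxymethyl stands apart. Nothing measured here accounts for these numbers. Still open, going by these compounds, is whether an amine or a longer chain in place of the carbamoyl would alter the effect, and whether a methyl ester would match the benzyl ester.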